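Replacing 2,4-dimethylphenyl with benzamido in compound 4

The source may hold more compounds than are shown below. What is called first, only, known or untested is meant among the compounds shown, and "the series" means these compounds.

Values so far in a functional assay on A549 cells (Homo sapiens) for antiproliferative activity, read by MTT assay; on this read-out lower numbers stand for stronger inhibition and higher numbers for weaker inhibition:
- compound 1 `COc1cc2c(Oc3ccc(NC(=O)Nc4ccc(OC(F)(F)F)cc4)cc3)ccnc2cc1OCCCCCCC(=O)NO` gives 3130 nM
- compound 2 `COc1cc2c(Oc3ccc(NC(=O)Nc4ccccc4C(F)(F)F)cc3)ccnc2cc1OCCCCCCC(=O)NO` gives 5280 nM
- compound 3 `COc1cc2c(Oc3ccc(NC(=O)Nc4ccc(C)cc4C)cc3)ccnc2cc1OCCCCCCC(=O)NO` gives 5490 nM

Compound 3, at 5490 nM, is not separated from the other two compounds: the scatter covers both a 1.8-fold higher number from compound 1 to compound 3 (0.24 log units; within the scatter) and a 1.0-fold higher number from compound 2 to compound 3 (0.02 log units; within the scatter). Compound 4 `COc1cc2c(Oc3ccc(NC(=O)NNC(=O)c4ccccc4)cc3)ccnc2cc1OCCCCCCC(=O)NO` has not yet been measured. It carries benzamido in place of 2,4-dimethylphenyl on an amide-type nitrogen.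

Going by the values given here, three measured steps bear on this change, each exchanging one substituted phenyl for another at that same place: the two above and a 1.7-fold higher number from compound 1 to compound 2 (0.23 log units; within the scatter). All three stay within the scatter, so across these compounds this assay has shown little response to the group there. None of them replaces a phenyl with benzamido, however, so the data hold no direct measure of this change and the expectation remains loose. Starting from compound 3 at 5490 nM, no step beyond the scatter is expected in either direction. The expected step is a 1.2-fold lower number from compound 3 to compound 4 (0.09 log units; within the scatter), an estimate that lies within the scatter. Compound 4 is estimated at 4500 nM, with an expected range of 1800 nM to 11000 nM.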

Compound 4, half-maximal inhibitory concentration: 2820 nM
Estimate against measurement, compound 4: 1.6-fold (0.20 log units) above; low and high end bracket the measured number.
By their numbers in this assay, from the lowest: compounds 4, 1, 2 and 3 (each within the scatter of the next).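

Benzamido differs from the substituted phenyls in kind, placing a carbonyl and an additional nitrogen in the group and adding a hydrogen-bond donor and a hydrogen-bond acceptor, yet this assay still does not separate it from them: the exchange gives a 1.9-fold lower number from compound 3 to compound 4 (0.29 log units; within the scatter), a 1.9-fold lower number from compound 2 to compound 4 (0.27 log units; within the scatter) and a 1.1-fold lower number from compound 1 to compound 4 (0.05 log units; within the scatter). The lack of response at this amide-type nitrogen, earlier seen only among substituted phenyls, therefore also holds for this one group of a different type, though these four compounds alone cannot show how far it extends. Nothing available accounts for this lack of response.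

Going by these compounds, whether an amine, a carboxylic acid or a simple alkyl chain on this amide-type nitrogen would move the number beyond the scatter remains open, as does the effect of a trifluoromethyl or methyl group on the benzamido ring. All four compounds share the rest of their structure, so they also leave open how much of the antiproliferative effect depends on that shared part.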